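A few compounds are considered here, and "the series" means these few. Any claim that something is new, unique, unknown or untested is made for them only; others in the source may bear on it.

Measured compounds:
Compound 1 `O=C1c2ccccc2C(=O)N1C1C=C(C#Cc2ccccn2)CCC1` gives 5.8 nM in an assay for displacement of a labelled ligand from metabotropic glutamate receptor 5 (Rattus norvegicus); a higher number here means a weaker inhibitor, a lower number a stronger inhibitor.
Compound 2 `O=C(Oc1ccccc1)N1CC=C(C#Cc2ccccn2)CC1` gives 171 nM in this assay.
Compound 3 `Cc1cccc(S(=O)(=O)N2CC=C(C#Cc3ccccn3)CC2)c1` gives 13 nM in this assay.

Among these three values, compound 3 holds the second highest number. Its nearest neighbour is compound 1, whose number is lower by a gap beyond the scatter; compound 2 sits furthest away, with a much higher number.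

Compound 4 `O=S(=O)(c1ccc(Br)cc1)N1CC=C(C#Cc2ccccn2)CC1` has not yet been measured. Compared with compound 3, the change is 4-bromophenyl in place of 3-methylphenyl on a sulfonyl sulfur whose other neighbour is a sulfonamide nitrogen in a ring. Among the compounds with values here, no measured pair here reports what such a swap does, so the expected step of a 1.2-fold higher number from compound 3 to compound 4 (0.06 log units; within the scatter) is one within the scatter, with no clear direction. Compound 4 is therefore estimated at 15 nM, between 5 nM and 45 nM.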

Compound 4, inhibition constant: 3.1 nM
Compound 4: the middle estimate sits 4.8-fold (0.68 log units) above what was measured; the measured number lies below the stated range.
By their numbers in this assay, from the lowest: compounds 4 and 1 (each within the scatter of the next); then compound 3; then compound 2.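

In this assay the sulfonyl series shows a 4.2-fold lower number from compound 3 to compound 4 (0.62 log units; beyond the scatter) when 4-bromophenyl replaces 3-methylphenyl, so this place on the sulfonyl sulfur responds even to a swap between two groups with the same heavy-atom count. The swap changes both the substituent and its ring position, so this single step cannot separate the two. No available measurement explains the gain.

Still open, from the compounds shown here alone, is whether 4-methylphenyl or 3-bromophenyl would match either compound, which would separate those two changes. Also open, going by these compounds, is how a small alkyl group such as methyl would fare on the sulfonyl sulfur.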